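Series notes: amine-ring substituent change at the fused core

This account rests on a few compounds, and the source may have more. Where it says the series, first, only, none or still open, it means among the compounds named here.

Measured so far:
compound 1, `CC(C)OC(=O)N1CCC(Oc2ncnc3c2CCN3c2ccc(S(C)(=O)=O)cc2)CC1`, 154%
compound 2, `CC(C)S(=O)(=O)N1CCC(Oc2ncnc3c2CCN3c2ccc(S(C)(=O)=O)cc2F)CC1`, 62%
compound 3, `CC(C)OC(=O)N1CCC(Sc2ncnc3c2CCN3c2ccc(S(C)(=O)=O)cc2F)CC1`, 69%

In a functional assay on CHO-K1 cells with Glucose-dependent insulinotropic receptor (Homo sapiens) as the target, read by a luciferase reporter, with a stated time of 5 h (on this read-out higher numbers stand for larger maximal responses and lower numbers for smaller maximal responses), compound 1 gives the highest of the three numbers; compound 3 sits a gap beyond the scatter below it, and compound 2 lies further still. Going by the values given here, compounds 2 and 3 each differ from compound 1 in more than one place, so no single-change step can be read from them, and there is no pair of measured compounds that differ in only one place.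

Compound 4, `CSc1ccc(N2CCc3c(OC4CCN(C(=O)OC(C)C)CC4)ncnc32)cc1F`, has not been measured in this assay. It differs from compound 1 as follows: a group of 9 heavy atoms (7 carbon, 1 fluorine, 1 sulfur; one six-membered aromatic ring of carbon only) in place of a group of 10 heavy atoms (7 carbon, 2 oxygen, 1 sulfur; one six-membered aromatic ring of carbon only), on a nitrogen on an aromatic ring in a ring. The change at the nitrogen on the aromatic ring sits in the same part of the molecule where the fluorine-bearing compounds 2 and 3 also vary from compound 1, and both of those give smaller responses. Among the compounds with values here, the step from compound 1 to compound 4 is therefore expected to be downward and beyond the scatter, a number 59 percentage points lower from compound 1 to compound 4 (beyond the scatter), though the data give no direct single-change precedent. For compound 4 the estimated value in this assay is 95%, with a range from 45% to 150%.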

Compound 4, largest response reached (reported as percent of maximum), in percent of the reference or control that the assay uses: 121%
For compound 4 the middle estimate is 26 percentage points below the measured one; the range from low to high includes it.
By their numbers in this assay, from the lowest: compounds 2 and 3 (each within the scatter of the next); then compound 4; then compound 1.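

In this assay, going by these compounds alone, replacing the 4-(methylsulfonyl)phenyl group with the fluorine-bearing group of 9 heavy atoms, on a nitrogen on an aromatic ring in a ring, gives a number 33 percentage points lower from compound 1 to compound 4 (beyond the scatter), the only single-place step so far. The maximal response is therefore sensitive to the group at this position, yet compound 4 still gives 121%, so the 4-(methylsulfonyl)phenyl group is not essential for a substantial response in this set. Nothing available accounts for the size or direction of this step.

From the compounds shown here alone, the entering group differs from the leaving group in both its fluorine and its sulfur-bearing part, so the share of each in the step remains open. Also open, going by these compounds, is how a nitrile or a primary amine at this same place would compare with compound 1.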